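The compounds below may be only part of what the source reports. "The series", "measured", "known", "first", "only" and "open" are said of these compounds alone.

Compound 2 `Cc1nc(-c2cccc(F)c2)sc1COc1ccc2c(c1)OCC2CC(=O)O` is the stronger of the two measured compounds: in a functional assay on CHO cells for agonist activity at Free fatty acid receptor 1 (Homo sapiens), read by FLIPR and calcium flux, tested at 100 nM (a lower number here means a weaker effect, a higher number a stronger effect of the compound at the concentration tested), compound 2 gives 56.9%, while compound 1 `Cc1nc(-c2cccc3ccccc23)sc1COc1ccc2c(c1)OCC2CC(=O)O` gives 8.53%. For the measured compounds named here, the single step between them, a number 48.4 percentage points higher from compound 1 to compound 2 (beyond the scatter), shows that swapping the group on that aromatic carbon of the shared core can move the read-out a great deal.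

Compound 3 `COc1ccc(-c2nc(C)c(COc3ccc4c(c3)OCC4CC(=O)O)s2)cc1` differs from compound 2 by 4-methoxyphenyl in place of 3-fluorophenyl on an aromatic carbon. Going by the values given here, no measured step covers this particular exchange; the only step available, a number 48.4 percentage points higher from compound 1 to compound 2 (beyond the scatter), concerns a different pair of groups at the same aromatic carbon. It does show that this position is sensitive, so a change beyond the scatter in either direction cannot be ruled out. Both the leaving 3-fluorophenyl and the entering 4-methoxyphenyl contain one six-membered aromatic ring of carbon only, whereas compound 1 carried the two-ring naphthalen-1-yl and gave 8.53%, so compound 3 is expected to stay nearer to compound 2 than to compound 1. Compound 3 is therefore estimated at 45%, within 15% to 75%, which means an expected step of a number 11.9 percentage points lower from compound 2 to compound 3 (beyond the scatter).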

Compound 3, a percentage reported as activity, at one concentration (the size of the read-out at that concentration, not a potency): 46.8%
Estimate against measurement, compound 3: 1.8 percentage points below, and the stated range covers the measured number.
By their numbers in this assay, from the lowest: compound 1; then compound 3; then compound 2.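

A second single-ring group now sits on this aromatic carbon, and in this assay replacing 3-fluorophenyl with 4-methoxyphenyl gives a number 10.1 percentage points lower from compound 2 to compound 3 (beyond the scatter), a modest step that shows the read-out still responds to the substituent and its place on a single ring. Replacing the two-ring naphthalen-1-yl gives a number 38.3 percentage points higher from compound 1 to compound 3 (beyond the scatter), a large step, so among these three compounds both single-ring groups stand well above the two-ring group, and none of the three goes against that pattern. Nothing measured here explains either step.

The exchange between compound 2 and compound 3 changes both the substituent, fluorine or methoxy, and its number on the phenyl ring, so the compounds shown cannot separate these two changes, which 4-fluorophenyl or 3-methoxyphenyl at this carbon could begin to do. From the compounds shown here alone, it also remains open what groups without a phenyl ring would give here, such as an amine or a longer carbon chain.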